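The source may report more compounds than this note shows. Statements on the series, on what has been measured and on what is new or still open speak of the compounds shown alone.

In a functional assay on OCI-Ly3 cells (Homo sapiens) for inhibition, read by CellTiter-Glo, with stated times of 48 h and 96 h (a higher number here means a weaker inhibitor of growth, a lower number a stronger inhibitor of growth), compound 1 (`CC(C)[C@H](NC(=O)c1cccc(Br)c1)C(=O)N1CCC[C@H]1C(=O)N[C@@H](CCCNC(=N)N)C(=O)CF`) gives 530 nM and compound 2 (`CC(C)c1ccc(C(=O)N[C@H](C(=O)N2CCC[C@H]2C(=O)N[C@@H](CCCNC(=N)N)C(=O)CF)C(C)C)cc1`) gives 270 nM. These two numbers lie within the scatter of each other, so compound 1 has no clear rank between them. Compound 3 (`CC(C)[C@H](NC(=O)Nc1ccccc1)C(=O)N1CCC[C@H]1C(=O)N[C@@H](CCCNC(=N)N)C(=O)CF`) shares the core of compound 1 and differs from it by this change: anilino in place of 3-bromophenyl on a carbonyl carbon. The group on the carbonyl carbon thus turns from (3-bromophenyl)carbonyl into phenylcarbamoyl. Only one measured replacement bears on this place, and it amounts to a 2.0-fold lower number from compound 1 to compound 2 (0.29 log units; within the scatter). Going by the values given here, no measured compound carries the anilino group, so the data give no direct guide to its effect. With only compound 2 at 270 nM as a precedent, no change beyond the scatter is expected in this assay. The estimated step is a 1.2-fold lower number from compound 1 to compound 3 (0.07 log units; within the scatter). For compound 3 the expected value is 450 nM, with an estimated range of 150 nM to 1300 nM.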

Compound 3, concentration for 50% growth inhibition: 1520 nM
For compound 3 the middle estimate is 3.4-fold (0.53 log units) below the measured one; measured number outside the range, above it.
By their numbers in this assay, from the lowest: compounds 2 and 1 (each within the scatter of the next); then compound 3.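

In this assay, the change from 3-bromophenyl to anilino on the carbonyl carbon gives a 2.9-fold higher number from compound 1 to compound 3 (0.46 log units; beyond the scatter), and the change from 4-isopropylphenyl to anilino gives a 5.6-fold higher number from compound 2 to compound 3 (0.75 log units; beyond the scatter). Both steps lie beyond the scatter, so this position does respond to its substituent, which the earlier step between the two aryl groups, within the scatter, did not show. The anilino group carries 1 hydrogen-bond donor where the groups it replaces carry none, but no measurement shown accounts for the weaker growth inhibition.

Compound 3 has an unsubstituted ring, so the shown compounds do not separate the effect of the added nitrogen from that of losing the bromine or isopropyl substituent. A 3-bromoanilino group or a benzyl group at this place would bear on that question.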